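The source may report more compounds than this note shows. Statements on the series, on what has been measured and on what is new or still open speak of the compounds shown alone.

Compound 1, `Cc1cnc(C(=O)Nc2cccc3ccc(C)nc23)cn1`: in a functional assay on BXPC-3 cells (Homo sapiens) for inhibition, read by MTT assay, with a stated time of 72 h (on this read-out higher numbers stand for weaker inhibition and lower numbers for stronger inhibition), compound 1 gives > 10000 nM, which is a limit of the assay and not a number.
Compound 2, `Cc1cnc(C(=O)Nc2ccc(Br)c3cccnc23)cn1`: compound 2 gives > 10000 nM, again only a limit.
Compound 3, `Cc1ccc2cccc(NC(=O)c3cnccn3)c2n1`: compound 3 gives > 10000 nM, also a limit.

From compound 1 to compound 3 the change is hydrogen in place of methyl on an aromatic carbon. The step it made, a step that the two limits leave unreadable from compound 1 to compound 3, cannot be read because both values sit at the limit of > 10000 nM in this assay, at which 3 of the 3 values shown sit. Compound 4, `O=C(Nc1ccc(Br)c2cccnc12)c1cnccn1`, carries the same change, (hydrogen in place of methyl on an aromatic carbon), on the core of compound 2; the difference between the two cores of compound 1 and compound 2 is not broken down here. The step from compound 2 to compound 4 is expected to be a step that the limit leaves unreadable from compound 2 to compound 4, resting on the unreadable earlier step and on the limit of compound 2. Compound 4 is therefore estimated at 15000 nM, most likely reported again only as a limit.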

Compound 4, half-maximal inhibitory concentration: 7500 nM
Compound 4: middle estimate off by 2.0-fold (0.30 log units), on the high side, within the range that was stated.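

In this assay, putting hydrogen in place of methyl on the core of compound 2 gives an at least 1.3-fold lower number from compound 2 to compound 4 (0.12 log units; that floor lies within the scatter); the value of compound 2 is a limit of the assay and not a number, so only this floor can be read. The same change on the core of compound 1 cannot be read, because both of its values sit at a limit: the limit of > 10000 nM in this assay, at which 3 of the 4 values shown sit. Nothing here therefore shows that the change carries over between the two cores, or that it fails to.

As far as these compounds go, what remains open is how the series responds to other groups at this place. An amine or a carboxylic acid in place of the methyl of 5-methylpyrazin-2-yl is not among the compounds shown.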